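Amino in Place of Hydrogen on a Methoxy Nucleoside

The source may hold more compounds than are shown below. What is called first, only, known or untested is meant among the compounds shown, and "the series" means these compounds.

Compound 1: `Nc1nc(N)c2c(-c3ccoc3)cn([C@@H]3O[C@H](CO)[C@@H](O)[C@H]3O)c2n1` — > 20000 nM
Compound 2: `COc1nc(N)nc2c1c(-c1ccccc1)cn2[C@@H]1O[C@H](CO)[C@@H](O)[C@H]1O` — > 20000 nM
Compound 3: `COc1ncnc2c1c(-c1ccoc1)cn2[C@@H]1O[C@H](CO)[C@@H](O)[C@H]1O` — 1160 nM

All three compounds were tested in a functional assay on A549 cells (Homo sapiens), read by MTT assay, with a stated time of 72 h; on this read-out higher numbers stand for weaker inhibition and lower numbers for stronger inhibition. For compound 1 the assay reports only a limit, > 20000 nM, not a number. For compound 2 the result is likewise only a limit, > 20000 nM. Within the data shown here, compound 3 gives 1160 nM in this assay, the only measured number among the three, while the other two sit at the limit of > 20000 nM in this assay, at which 2 of the 3 values shown sit. Among the measured compounds shown here, compound 3 therefore stands alone as the one compound with a measurable value.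

Compound 4 `COc1nc(N)nc2c1c(-c1ccoc1)cn2[C@@H]1O[C@H](CO)[C@@H](O)[C@H]1O` has not yet been measured. It differs from compound 3 in one place: amino in place of hydrogen on an aromatic carbon. Compound 2 also carries an amino group on its core, and its result is a limit. Compound 1 carries an amino group at the same kind of position, and its result is a limit as well. Neither pair forms a single-change step with compound 4, so these values can only be set side by side.

On this basis the step from compound 3 to compound 4 is expected to weaken inhibition by a margin beyond the scatter, a 13-fold higher number from compound 3 to compound 4 (1.11 log units; beyond the scatter). Compound 4 is estimated at 15000 nM, with a range from 3000 nM to 60000 nM, and a real chance that only a limit is reported.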

Compound 4, half-maximal inhibitory concentration: > 20000 nM
Compound 4 ended at the assay's limit (the forecaster's own chance of this, stated with the estimate: 55%); middle value at least 1.3-fold (0.12 log units) away from the limit.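

In this assay, placing an amino group on the aromatic carbon between two ring nitrogen atoms, with the furan-3-yl and methoxy groups left unchanged, brings an at least 17-fold higher number from compound 3 to compound 4 (1.23 log units; beyond the scatter). Among these compounds, this is the first single-change step in the set, and it shows that this position does not tolerate every change: this one small group is enough to take the compound from a measured value to the end of the assay's range. The result for compound 4 is a limit, so the step fixes only a minimum size, and the steps from compound 2 and from compound 1 to compound 4 cannot be read, leaving compound 3 as the one measured number against a shared ceiling: the limit of > 20000 nM in this assay, at which 3 of the 4 values shown sit.

The compounds shown do not tell whether the loss belongs to the amino group alone or to any group at this position, a question that a methyl group, a fluorine atom or a methylamino group there could begin to answer. They also leave open whether an ethoxy group in place of methoxy on compound 3 would keep its measured inhibition.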